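Hydrazone aryl variation on the shared core

The source may report more compounds than this note shows. Statements on the series, on what has been measured and on what is new or still open speak of the compounds shown alone.

Measured so far:
Compound 1 `CN(C)CCn1cnnc1-c1cc(Oc2ccc(NC(=O)N/N=C/c3ccc(F)cc3)cc2F)ccn1`, 1790 nM in a functional assay on A549 cells (Homo sapiens) for cytotoxicity, read by MTT assay, with a stated time of 72 h; on this read-out lower numbers stand for stronger inhibition and higher numbers for weaker inhibition.
Compound 2 `CN(C)CCn1cnnc1-c1cc(Oc2ccc(NC(=O)N/N=C/c3ccc(O)cc3O)cc2F)ccn1`, 12700 nM in this assay.

Compound 1 stands lowest of the two numbers measured; its nearest neighbour is compound 2, reached by a 7.1-fold higher number from compound 1 to compound 2 (0.85 log units; beyond the scatter). That step is the only one recorded, and it is the only one that bears on the change now in question, since both alter the aryl group on the hydrazone carbon.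

Compound 3 `Cc1cc(/C=N/NC(=O)Nc2ccc(Oc3ccnc(-c4nncn4CCN(C)C)c3)c(F)c2)cc(C)c1O` differs from compound 1 as follows: 4-hydroxy-3,5-dimethylphenyl in place of 4-fluorophenyl on a carbon with a double bond to nitrogen. Within the data shown here, compound 3 keeps one hydroxyl on the ring and adds two methyls, whereas compound 2 carried two hydroxyls and no methyls, so the single recorded step is only a partial guide. Compound 2 showed a 7.1-fold higher number from compound 1 to compound 2 (0.85 log units; beyond the scatter), so a loss in this assay is expected for compound 3 as well. For compound 3 the expected step is smaller, estimated as a 2.2-fold higher number from compound 1 to compound 3 (0.35 log units; beyond the scatter). The number expected for compound 3 in this assay is 4000 nM, within a range from 1500 nM to 11000 nM.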

Compound 3, half-maximal inhibitory concentration: 1640 nM
Compound 3: the middle estimate sits 2.4-fold (0.39 log units) above what was measured; the measured number falls inside the stated range.
By their numbers in this assay, from the lowest: compounds 3 and 1 (each within the scatter of the next); then compound 2.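

In this assay, a hydroxyl on the aryl ring at this carbon does not by itself go with a higher number: the change gives a 1.1-fold lower number from compound 1 to compound 3 (0.04 log units; within the scatter) and leaves 4-hydroxy-3,5-dimethylphenyl and 4-fluorophenyl indistinguishable here. The same group set against 2,4-dihydroxyphenyl gives a 7.7-fold lower number from compound 2 to compound 3 (0.89 log units; beyond the scatter) and so places compound 2 alone at the high end of the three, which shows that the effect depends on the substitution of the ring and not simply on a hydroxyl being present. No measurement at hand accounts for this difference.

The compounds shown do not separate the hydroxyl from the two methyls, since a ring carrying the hydroxyl without the methyls is absent from them. On these data alone, how an amine or a carboxylic acid on this ring would read remains open.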